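Propyl to tert-Butyl on the Hydroxy Side Chain

A few compounds are considered here, and "the series" means these few. Any claim that something is new, unique, unknown or untested is made for them only; others in the source may bear on it.

Measured compounds:
compound 1, `CC(C)(C)[C@@H](O)C(=O)N1Cc2ccccc2[C@H]1C(=O)NCc1cc(Cl)ccc1-n1nnnn1`: 9 10^-6 cm/s
compound 2, `CCCC[C@@H](O)C(=O)N1N=CC[C@H]1C(=O)NCc1cc(Cl)ccc1-n1cnnn1`: 9.8 10^-6 cm/s

Of the compounds shown here, two have so far been measured. In an ADME assay on Caco-2 cells (Homo sapiens) for permeability, read by LC-MS, in the apical to basolateral direction, with a stated time of 60 min, at pH 6.5 (a higher number here means that the compound crosses the layer faster, a lower number that the compound crosses the layer more slowly), compound 1 gives 9 10^-6 cm/s. In this assay compound 2 gives 9.8 10^-6 cm/s. Compound 2 holds the larger of the two numbers, but the gap to compound 1 lies within the usual scatter of repeated measurements, so the two compounds cannot be told apart on this assay and no order between them can be claimed. The two share neither a single-point difference nor any step that could be read as a trend.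

Compound 3, `CC(C)(C)C[C@@H](O)C(=O)N1N=CC[C@H]1C(=O)NCc1cc(Cl)ccc1-n1cnnn1`, differs from compound 2 in one place: tert-butyl in place of propyl on a saturated chain carbon, two bonds along the chain from a carbonyl carbon and an oxygen on a saturated carbon. Among the measured compounds shown here, no measured pair shows the effect of such a change on this assay, so the expectation rests on the near-identity of compound 1 and compound 2 alone. The step of a 1.1-fold higher number from compound 2 to compound 3 (0.05 log units; within the scatter) is expected to be small, upward if anything, and likely within the scatter. Compound 3 is therefore estimated at 11 10^-6 cm/s, with a range from 6 10^-6 cm/s to 20 10^-6 cm/s.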

Compound 3, apparent permeability: 24 10^-6 cm/s
Beside the measured number, compound 3's estimate is 2.2-fold (0.34 log units) below it; the measured number lies above the stated range.
By their numbers in this assay, from the lowest: compounds 1 and 2 (each within the scatter of the next); then compound 3.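

Among the compounds shown here, replacing propyl with tert-butyl on a saturated chain carbon, two bonds along the chain from a carbonyl carbon and an oxygen on a saturated carbon, gives in this assay a 2.4-fold higher number from compound 2 to compound 3 (0.39 log units; beyond the scatter), a modest step but the first single-place change here that can be read, and it lies beyond the scatter. It shows that the number in this assay responds to the group at this position, which the earlier pair could not show, as compound 1 and compound 2 differ in more than one place. No measurement shown here accounts for the rise, so this single step records the size and direction of the change and no reason for it.

As far as these compounds go, whether a longer chain, a cyclopropyl group or an amine at the same place would move the number in the same direction remains open. Also open, from the compounds shown here alone, is whether tert-butyl would give a similar step on the core of compound 1, and whether the rise would hold at another pH or in the opposite direction across the cell layer.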